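Propyl to methyl on the cyanoguanidine in a pyridazinone series

A few compounds are considered here, and "the series" means these few. Any claim that something is new, unique, unknown or untested is made for them only; others in the source may bear on it.

Compound 1 `C/N=C(/NC#N)NCCCCCn1nc(-c2ccccc2)ccc1=O` gives 47.6% in a functional assay on the whole organism with Rattus norvegicus as the target, at a dose of 100 mg/kg; on this read-out higher numbers stand for more inhibition at the one dose given (going by the name of the read-out) and lower numbers for less inhibition. Compound 2 `CCC/N=C(/NC#N)NCCCCCn1nc(-c2ccccc2)ccc1=O` gives 27.5% in this assay; the change from compound 2 to compound 1 is hydrogen in place of ethyl on a saturated chain carbon bound to a double-bonded nitrogen and makes a step of a number 20.1 percentage points higher from compound 2 to compound 1 (beyond the scatter). Compound 3 `CCC/N=C(/NC#N)NCCCn1nc(C)ccc1=O` gives 17.5% in this assay; the difference between the core of compound 3 and that of compound 2 is not broken down here. Compound 4 `C/N=C(/NC#N)NCCCn1nc(C)ccc1=O` is not yet measured in this assay; it differs from compound 3 by hydrogen in place of ethyl on a saturated chain carbon bound to a double-bonded nitrogen, the same change as from compound 2 to compound 1. Going by the values given here, because the earlier step was a number 20.1 percentage points higher from compound 2 to compound 1 (beyond the scatter), a step of a number 15.5 percentage points higher from compound 3 to compound 4 (beyond the scatter) in this assay is expected for compound 4, somewhat smaller since only one pair supports it. Compound 4 is estimated at 33% in this assay, between 18% and 50%.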

Compound 4, a percentage reported as inhibition, in the whole organism at one dose (the size of the read-out at that dose, not a potency): 6.8%
Compound 4: the middle estimate sits 26.2 percentage points above what was measured, outside the stated range (below it).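

In this assay, the change from propyl to methyl gives a number 10.7 percentage points lower from compound 3 to compound 4 (beyond the scatter), which runs opposite to the step on the other core. The change therefore does not carry over between these two cores with a constant size or direction: the same change on two cores in this assay, a number 20.1 percentage points higher (beyond the scatter) from compound 2 to compound 1 and a number 10.7 percentage points lower (beyond the scatter) from compound 3 to compound 4, 30.8 percentage points apart, beyond the scatter of two such steps This rests on a single pair per core, so it shows that the earlier step cannot be transferred here, but not which of the differences between the cores matters or how the change behaves on any further core.

Still open, on these data alone, is how butyl or cyclopropyl in place of propyl on the cyanoguanidine would read on either core. A third core would also be needed to show whether either direction recurs.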